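The compounds below may be only part of what the source reports. "The series", "measured", "known", "first", "only" and "open" are said of these compounds alone.

Of the compounds shown here, two that share one core have been tested in a functional assay on HCT-15 cells (Homo sapiens) for cytotoxicity; on this read-out lower numbers stand for stronger inhibition of growth and higher numbers for weaker inhibition of growth. Compound 1 `CCCCCCCCC(=O)N1c2ccccc2CC1C(=O)Nc1ccc(C(F)(F)F)cc1` gives 2070 nM. Compound 2 `Cc1ccc(S(=O)(=O)N2c3ccccc3CC2C(=O)Nc2ccc(C(F)(F)F)cc2)cc1` reaches only a limit of the assay, > 10000 nM. Among the compounds with values here, the single measured step, an at least 4.8-fold higher number from compound 1 to compound 2 (0.68 log units; beyond the scatter), carries the number out of the measured range. Compound 2 therefore sits at the limit of > 10000 nM in this assay, at which 1 of the 2 values shown sits. Compound 3 `Cc1ccc(S(=O)(=O)N2c3ccccc3CC2C(=O)Nc2cc(Cl)cc(Cl)c2)cc1` differs from compound 2 in one place: 3,5-dichlorophenyl in place of 4-(trifluoromethyl)phenyl on an amide-type nitrogen. Within the data shown here, the only measured step concerns the group on the nitrogen in the ring, not the amide-type nitrogen, so no measured step bears directly on the change to compound 3. Because compound 2 already stands at the limit of > 10000 nM in this assay, at which 1 of the 2 values shown sits, compound 3 is expected to come out at or near that limit, with a step that the limit leaves unreadable from compound 2 to compound 3 that is not expected to reach beyond the scatter. The estimate for compound 3 is 15000 nM, in a range from 5000 nM to 50000 nM.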

Compound 3, concentration for 50% growth inhibition: > 10000 nM
Compound 3 was reported as a limit; the forecaster's own chance of this, stated with the estimate: 70%; the middle value lies beyond the limit too.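

In this assay, within the data shown here, compound 3, like compound 2, reaches only a limit of the assay, so no step between the two can be read: the limit of > 10000 nM in this assay, at which 2 of the 3 values shown sit.

The compounds shown leave open whether 3,5-dichlorophenyl and 4-(trifluoromethyl)phenyl on the amide-type nitrogen differ at all in inhibition of growth.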